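The compounds below may be only part of what the source reports. "The series", "measured", "known", "first", "only" and "open" are said of these compounds alone.

For the measured compounds named here, in a functional assay on CWR22R cells (Homo sapiens) for antiproliferative activity, with a stated time of 96 h (a higher number here means a weaker inhibitor, a lower number a stronger inhibitor), compound 1 (`Cc1cc(=O)oc2cc(OCC(=O)c3ccccc3C(F)(F)F)ccc12`) gives 20400 nM, the only number so far. Compound 2 (`COc1cccc(C(=O)COc2ccc3c(C(F)(F)F)cc(=O)oc3c2)c1`) is reported as "not active" (no number reported). Compound 3 (`COc1ccc(C(=O)COc2ccc3c(C(F)(F)F)cc(=O)oc3c2)cc1`) is also reported as "not active" (no number reported), so it has no number of its own and shares that result with one other compound. Compound 4 (`Cc1ccc(C(=O)COc2ccc3c(C(F)(F)F)cc(=O)oc3c2)cc1`) differs from compound 3 by a single change: methyl in place of methoxy on an aromatic carbon. Going by the values given here, without a number for compound 3, no step can be sized. Only a small gain is expected, leaving a weak inhibitor at best, and another result without a number is quite possible. If a number is reported, compound 4 is expected near 30000 nM, with an estimated range of 12000 nM to 75000 nM.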

Compound 4, half-maximal inhibitory concentration: "not active" (no number reported)
The entry for compound 4 holds no number, and the estimate cannot be compared.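

Compound 3 and compound 4 both come without a number, so no step can be read between them. As far as these compounds go, whether changing 4-methoxyphenyl to 4-methylphenyl affects activity stays open, and no measured evidence bears on this result.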